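From Fluoromethyl to (Piperidin-1-yl)methyl: Expecting Weak Binding

A few compounds are considered here, and "the series" means these few. Any claim that something is new, unique, unknown or untested is made for them only; others in the source may bear on it.

Compound 1 `Fc1ccc(-c2ccc(-c3cn([C@H]4CN5CCC4CC5)nn3)s2)cn1` gives > 1000 nM in an assay on a protein complex for displacement of a labelled ligand from Neuronal acetylcholine receptor; alpha4/beta2 (Homo sapiens), read by radiometric assay, with a stated time of 120 min; on this read-out higher numbers stand for weaker inhibition and lower numbers for stronger inhibition.
Compound 2 `FCc1ccc(-c2ccc(-c3cn([C@H]4CN5CCC4CC5)nn3)s2)cc1` gives > 1000 nM in this assay.

Neither of these values is a number; each is a limit of this assay. For the measured compounds named here, compound 2 therefore stands at the limit, and the one further value shown is also a limit, which is captured by the limit of > 1000 nM in this assay, at which 2 of the 2 values shown sit. Because of this, the step that the two limits leave unreadable from compound 1 to compound 2 cannot be read in size or direction.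

Compound 3 `c1cc(-c2ccc(-c3cn([C@H]4CN5CCC4CC5)nn3)s2)ccc1CN1CCCCC1` differs from compound 2 by piperidin-1-yl in place of fluoro on a saturated chain carbon bound to an aromatic carbon. The same difference, cut one bond further out, reads fluoromethyl to (piperidin-1-yl)methyl.

Going by the values given here, no measured step bears on this change in a readable way, since the only step is hidden by the two limits. Among the compounds with values here, the sole guidance is that compound 2 sits at the limit of this assay. The step from compound 2 to compound 3 is therefore expected to be a step that the limit leaves unreadable from compound 2 to compound 3, with a clear direction not predictable. Compound 3 is expected to give about 3000 nM in this assay. For compound 3 the estimated range runs from 500 nM to 20000 nM, with a good chance that only a limit is reported.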

Compound 3, inhibition constant: 1000 nM
Estimate against measurement, compound 3: 3.0-fold (0.48 log units) above, within the range that was stated.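

For the compounds shown here, putting piperidin-1-yl in place of fluoro, on a saturated chain carbon bound to an aromatic carbon, gives a number no higher from compound 2 to compound 3 (the limit leaves the size open), and in this assay compound 3 is the only one of the three compounds to give a number, 1000 nM. Compound 2 gives > 1000 nM, which is a limit and not a number, so the size of this step cannot be read, and neither can the size of the step between the two limit compounds. The change therefore shows that this place can carry a much larger group, one with a six-membered non-aromatic ring and a nitrogen, while binding remains weak and the number for compound 3 stands right at the edge of what the other compounds show: the limit of > 1000 nM in this assay, at which 2 of the 3 values shown sit.

The compounds shown leave open whether the ring of piperidin-1-yl matters or only its nitrogen. An open-chain amine such as dimethylamino, or morpholin-4-yl with an oxygen in its ring, would be needed on the same chain carbon to separate these two readings and to show whether binding can move clearly past this level.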